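A few compounds are considered here, and "the series" means these few. Any claim that something is new, unique, unknown or untested is made for them only; others in the source may bear on it.

Three compounds of one series have been run in an ADME assay on microsomes from liver (Homo sapiens) for metabolic stability, read by HPLC, using NADPH, with a stated time of 60 min, tested at 1 uM, in the presence of a further agent that is not named here; a lower number here means slower removal, a higher number faster removal of the compound. Compound 1, `Cc1cc(-c2ccccn2)cc(C(=O)NNS(=O)(=O)c2ccccc2)c1F`, gives 27 uL/min in this assay. Going by the values given here, compound 2, `C=CCOc1cc(C)c(F)c(C(=O)NNS(=O)(=O)c2ccccc2)c1`, gives 73 uL/min, and the single change between them, allyloxy in place of pyridin-2-yl on an aromatic carbon, produced a 2.7-fold higher number from compound 1 to compound 2 (0.43 log units; beyond the scatter). Compound 3, `Cc1cc(C(=O)NNS(=O)(=O)c2ccccc2F)cc(-n2cc(F)cn2)c1`, gives 143 uL/min, the highest number of the three; against compound 2 the gap falls within the scatter, while against compound 1 it lies beyond it, so compound 3 is removed faster than compound 1 but cannot be ranked against compound 2.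

Compound 4, `CCOc1cc(C)cc(C(=O)NNS(=O)(=O)c2ccccc2F)c1`, has not yet been measured. Its difference from compound 3 is ethoxy in place of 4-fluoro-1H-pyrazol-1-yl on an aromatic carbon. Among the compounds with values here, the only measured step that bears on it is the one from compound 1 to compound 2, where an aromatic ring attached to the core was replaced by an oxygen-linked chain and the number rose modestly. The present change is of the same kind, a ring giving way to an oxygen-linked chain, though the ring that leaves and the chain that enters are different, so the comparison is loose. On that basis a modest rise is expected, a 1.5-fold higher number from compound 3 to compound 4 (0.19 log units; within the scatter), and compound 4 is estimated at 220 uL/min in this assay, with a range from 110 uL/min to 440 uL/min.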

Compound 4, intrinsic clearance in a liver preparation (reported as CLH), per the amount of preparation that the assay uses: 181 uL/min
The estimate for compound 4 lay 1.2-fold (0.08 log units) above the measured number, within the range that was stated.
By their numbers in this assay, from the lowest: compound 1; then compounds 2, 3 and 4 (each within the scatter of the next, the first and the last beyond it).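

Putting ethoxy in place of 4-fluoro-1H-pyrazol-1-yl on this aromatic carbon gives, in this assay, a 1.3-fold higher number from compound 3 to compound 4 (0.10 log units; within the scatter), so compounds 3 and 4 cannot be told apart by this read-out. At this place, meta to a large group and meta to a methyl group, a five-membered aromatic ring of 6 heavy atoms and a chain of 3 heavy atoms with no ring therefore give numbers within the scatter of each other, which shows that a ring giving way to an oxygen-linked chain need not move the number beyond the scatter, as it did in the earlier step, a 2.7-fold higher number from compound 1 to compound 2 (0.43 log units; beyond the scatter), where a different ring and chain were involved. Nothing available here explains why these two steps differ in size.

Still open, going by these compounds, is whether a longer chain such as butoxy, or an amine or a carboxylic acid, on this same aromatic carbon would move the number beyond the scatter. Also open, on these data alone, is whether ethoxy would give the same result on the core of compound 1, which differs from that of compounds 3 and 4 in more than one place.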